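The source may report more compounds than this note shows. Statements on the series, on what has been measured and on what is new or still open speak of the compounds shown alone.

Compound 1 `CCC1c2cc(Cl)ccc2C(=O)N1c1cccnc1`: 121 nM
Compound 2 `CC1c2cc(Cl)ccc2C(=O)N1c1cccnc1`: 123 nM

In an assay on cells for inhibition of cytochrome P450 11B2, mitochondrial (Homo sapiens), read by HTRF (on this read-out higher numbers stand for weaker inhibition and lower numbers for stronger inhibition), compound 2 gives 123 nM, the higher of the two numbers, with compound 1 nearest at 121 nM; the step of a 1.0-fold higher number from compound 1 to compound 2 (0.01 log units; within the scatter) lies within the scatter. Compound 3 `O=C1c2ccc(Cl)cc2C(C2CC2)N1c1cccnc1` differs from compound 2 by cyclopropyl in place of methyl on a saturated ring carbon. Among the measured compounds shown here, the one measured step that bears on this, a 1.0-fold higher number from compound 1 to compound 2 (0.01 log units; within the scatter), changed the group on the same saturated ring carbon without moving the number beyond the scatter, so the step of a 1.1-fold higher number from compound 2 to compound 3 (0.02 log units; within the scatter) is expected to stay within the scatter as well. Compound 3 is therefore estimated at 130 nM, with a range from 60 nM to 300 nM.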

Compound 3, half-maximal inhibitory concentration: 161 nM
For compound 3 the middle estimate is 1.2-fold (0.09 log units) below the measured one, and the stated range covers the measured number.
By their numbers in this assay, from the lowest: compounds 1, 2 and 3 (each within the scatter of the next).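

In this assay, placing a ring on the saturated ring carbon next to the ring nitrogen leaves the number within the scatter: cyclopropyl in place of methyl gives a 1.3-fold higher number from compound 2 to compound 3 (0.12 log units; within the scatter) and cyclopropyl in place of ethyl gives a 1.3-fold higher number from compound 1 to compound 3 (0.12 log units; within the scatter) at the same carbon. Methyl, ethyl and cyclopropyl are therefore not told apart at this position on this read-out. Nothing available explains why these numbers stay together.

Going by these compounds, whether a phenyl ring, an amine or a carboxylic acid at this carbon would move the number beyond the scatter remains open.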